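This account rests on a few compounds, and the source may have more. Where it says the series, first, only, none or still open, it means among the compounds named here.

Compounds measured in a functional assay on DU-145 cells (Homo sapiens) for inhibition, read by trypan blue exclusion, with a stated time of 96 h (a higher number here means a weaker inhibitor of growth, a lower number a stronger inhibitor of growth), are these:
- compound 1 `O=C(/C(=C\c1c[nH]c2ccc(Cl)cc12)SCc1ccc(F)cc1)c1ccc(Br)cc1` gives 1000 nM
- compound 2 `CN(C)c1ccc(/C=C(/SCc2ccc(F)cc2)C(=O)c2ccc(Br)cc2)cc1` gives 50000 nM
- compound 3 `O=C(/C(=C\c1ccc2ccccc2n1)SCc1ccc(F)cc1)c1ccc(Br)cc1` gives 25000 nM

Compound 3, at 25000 nM, stands far from compound 1 and within the scatter of compound 2. The two gaps are a 25-fold higher number from compound 1 to compound 3 (1.40 log units; beyond the scatter) and a 2.0-fold lower number from compound 2 to compound 3 (0.30 log units; within the scatter), and this assay thus separates compound 1 alone from the other two.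

The next compound is compound 4 `Cc1ccc(C)c(/C=C(/SCc2ccc(F)cc2)C(=O)c2ccc(Br)cc2)c1`. The structural change is 2,5-dimethylphenyl in place of quinolin-2-yl on a double-bonded chain carbon bound to a double-bonded chain carbon. Like compounds 2 and 3, compound 4 lacks the 5-chloro-1H-indol-3-yl group of compound 1.

Two large steps involve the loss of that group: a 50-fold higher number from compound 1 to compound 2 (1.70 log units; beyond the scatter) and a 25-fold higher number from compound 1 to compound 3 (1.40 log units; beyond the scatter). The step that most resembles the present one, an exchange between two groups other than 5-chloro-1H-indol-3-yl, is a 2.0-fold lower number from compound 2 to compound 3 (0.30 log units; within the scatter) and stays within the scatter. For the measured compounds named here, no measured compound carries 2,5-dimethylphenyl, so this is only a weak guide. In this assay no step beyond the scatter is therefore expected, in either direction.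

The estimate for compound 4 is 25000 nM, with an expected range from 6000 nM to 80000 nM. The estimated step is no change at the digits printed from compound 3 to compound 4 (within the scatter) (an expectation, not a measurement).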

Compound 4, concentration for 50% growth inhibition: 1000 nM
For compound 4 the middle estimate is 25-fold (1.40 log units) above the measured one; the measured number lies below the stated range.
By their numbers in this assay, from the lowest: compounds 1 and 4 (each within the scatter of the next); then compounds 3 and 2 (each within the scatter of the next).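

In this assay, large steps at this double-bonded chain carbon no longer depend on the loss of 5-chloro-1H-indol-3-yl: the change to 2,5-dimethylphenyl gives a 25-fold lower number from compound 3 to compound 4 (1.40 log units; beyond the scatter), and the exchange for 4-(dimethylamino)phenyl gives a 50-fold lower number from compound 2 to compound 4 (1.70 log units; beyond the scatter). Compound 1 no longer stands alone, since the exchange of 5-chloro-1H-indol-3-yl for 2,5-dimethylphenyl gives no change at the digits printed from compound 1 to compound 4 (within the scatter), so among these compounds the low number does not require the indole group and can occur with a group of carbon atoms only, although compound 2 shows that a substituted phenyl group does not guarantee it. Nothing available accounts for why these groups differ so widely.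

The compounds shown do not tell whether both methyl groups of compound 4 are needed, a question that unsubstituted phenyl or a phenyl group with a single methyl could address. They also leave open whether other groups at this carbon, such as 2,5-dichlorophenyl or 2,5-dimethoxyphenyl, would keep the number of compound 4 or return it to that of compound 3.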